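Piperazine replacing the thiazoline on the acetamide carbon

The source may hold more compounds than are shown below. What is called first, only, known or untested is meant among the compounds shown, and "the series" means these compounds.

Of the compounds shown here, three of the shared core have been measured in a functional assay on HT-29 cells (Homo sapiens) for cytotoxicity, read by MTT assay, with a stated time of 24 h, tested at 80 ug/mL; on this read-out higher numbers stand for a stronger effect at the one concentration tested and lower numbers for a weaker effect. Compound 1 `Cc1ccc2oc(SCC(=O)Nc3ccc(-c4nc(-c5ccccc5)c(-c5ccccc5)n4C)cc3)nc2c1` gives 69.8%, compound 2 `Cn1nnnc1SCC(=O)Nc1ccc(-c2nc(-c3ccccc3)c(-c3ccccc3)n2C)cc1` gives 89%, and compound 3 `Cn1c(-c2ccc(NC(=O)CSC3=NCCS3)cc2)nc(-c2ccccc2)c1-c1ccccc1` gives 75.2%. Compound 3 stands second highest of the three: its nearest neighbour is compound 1, a number 5.4 percentage points higher from compound 1 to compound 3 (within the scatter), while against compound 2 the gap is beyond the scatter, a number 13.8 percentage points lower from compound 2 to compound 3 (beyond the scatter). The largest step in the set is a number 19.2 percentage points higher from compound 1 to compound 2 (beyond the scatter).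

Compound 4 `CCN1CCN(CC(=O)Nc2ccc(-c3nc(-c4ccccc4)c(-c4ccccc4)n3C)cc2)CC1` is not yet measured. It differs from compound 3 by a group of 8 heavy atoms (6 carbon, 2 nitrogen; one six-membered non-aromatic ring with 2 hetero atoms) in place of a group of 6 heavy atoms (3 carbon, 1 nitrogen, 2 sulfur; one five-membered non-aromatic ring with 2 hetero atoms), on a saturated chain carbon bound to a carbonyl carbon. All three measured steps exchange a group on a sulfur, and none removes the sulfur-linked group in favour of a nitrogen-linked ring on the chain carbon, so they bear only loosely on this change. They show that exchanging this part of the molecule moves this assay by modest amounts at most, and the wide range of the estimate reflects the missing closer precedent. Compound 4 is therefore expected near compound 3, with a number 5.2 percentage points lower from compound 3 to compound 4 (within the scatter) as the expected step. The estimate for compound 4 is 70%, within 45% to 90%.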

Compound 4, a percentage reported as activity, at one concentration (the size of the read-out at that concentration, not a potency): 51.2%
Compound 4: middle estimate off by 18.8 percentage points, on the high side; low and high end bracket the measured number.
By their numbers in this assay, from the lowest: compound 4; then compounds 1 and 3 (each within the scatter of the next); then compound 2.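

Placing 4-ethylpiperazin-1-yl on the saturated chain carbon bound to a carbonyl carbon lowers the read-out in this assay against all three sulfur-linked partners: a number 24 percentage points lower from compound 3 to compound 4 (beyond the scatter), a number 18.6 percentage points lower from compound 1 to compound 4 (beyond the scatter) and a number 37.8 percentage points lower from compound 2 to compound 4 (beyond the scatter). The earlier steps shown here exchanged only the group on the sulfur, whereas this change replaces the whole sulfur-linked group, and it places compound 4 beyond the scatter of every other compound, at the low end of the series. No measurement shown here accounts for the drop.

The compounds shown leave open whether the lower number follows the piperazine ring, its ethyl group or the loss of the sulfur link. A morpholin-4-yl or a 4-methylpiperazin-1-yl group on the same carbon would help to separate these.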